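Hydroxy for amino on the shared core of compound 2

The compounds below may be only part of what the source reports. "The series", "measured", "known", "first", "only" and "open" are said of these compounds alone.

In a physicochemical assay for lipophilicity, at pH 7.4 (a lower number here means a more polar compound, a higher number a more lipophilic compound), compound 2 `CCc1ccc(N(CC(C)C)S(=O)(=O)c2ccc3c(c2)C(N)CC(C2CCOCC2)O3)cc1` gives 3.08, the lower of the two measured numbers; compound 1 `CC(C)CN(c1ccc(N(C)C)cc1)S(=O)(=O)c1ccc2c(c1)C(O)CC(C1CCOCC1)O2` gives 3.51, a value that lies beyond the usual scatter above it. Compound 3 `CCc1ccc(N(CC(C)C)S(=O)(=O)c2ccc3c(c2)C(O)CC(C2CCOCC2)O3)cc1` is not yet measured. It differs from compound 2 in one place: hydroxy in place of amino on a saturated ring carbon. Among the compounds with values here, no step between measured compounds that differ only in this way is available. He expects this change to raise the number in this assay by a modest amount, a step from compound 2 to compound 3 estimated at a number 0.52 log units higher from compound 2 to compound 3 (beyond the scatter). For compound 3 he therefore estimates 3.6, within a range of 3.2 to 4.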

Compound 3, distribution coefficient: 4.12
For compound 3 the middle estimate is 0.52 log units below the measured one, and the stated range ends below it.
By their numbers in this assay, from the lowest: compound 2; then compound 1; then compound 3.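

In this assay, within the data shown here, hydroxy in place of amino on a saturated ring carbon gives a number 1.04 log units higher from compound 2 to compound 3 (beyond the scatter) and is a large step, the first reading of this change at this position on the shared core. With the hydroxy group held in place, ethyl in place of dimethylamino on an aromatic carbon gives a number 0.61 log units higher from compound 1 to compound 3 (beyond the scatter) as a modest step. Nothing measured here accounts for either step. As far as these compounds go, whether hydroxy in place of amino reads the same with dimethylamino on the aromatic carbon remains open. So does how a methoxy group or an acetamide would read on the saturated ring carbon.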